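The source may report more compounds than this note shows. Statements on the series, on what has been measured and on what is new or still open speak of the compounds shown alone.

Measured so far in a functional assay on HeLa cells (Homo sapiens) for antiproliferative activity, with a stated time of 24 h; a higher number here means a weaker inhibitor, a lower number a stronger inhibitor

compound 1 `NC(=O)c1c(NC(=O)c2ccccc2Cl)sc2c1CCN(Cc1ccc([N+](=O)[O-])cc1)C2` gives 46100 nM
compound 2 `NC(=O)c1c(NC(=O)c2ccccc2Cl)sc2c1CCN(Cc1c(Cl)cccc1Cl)C2` gives 28800 nM

Compound 2 has only compound 1 to stand against, and the two values lie within the scatter of each other (a 1.6-fold lower number from compound 1 to compound 2 (0.20 log units; within the scatter)). The next compound is compound 3 (`NC(=O)c1c(NC(=O)c2ccccc2Cl)sc2c1CCN(Cc1ccc(Cl)cc1Cl)C2`). It differs from compound 2 in a single group (2,4-dichlorophenyl in place of 2,6-dichlorophenyl on a saturated chain carbon bound to an amine nitrogen in a ring), with 2,4-dichlorophenyl in place of 2,6-dichlorophenyl on a saturated chain carbon bound to an amine nitrogen in a ring. Among the measured compounds shown here, no compound carrying 2,4-dichlorophenyl has been measured, so only one step bears on this change, the one made at the same place (a 1.6-fold lower number from compound 1 to compound 2 (0.20 log units; within the scatter)). That exchange of 4-nitrophenyl for 2,6-dichlorophenyl stayed within the scatter, so no step beyond the scatter is expected in this assay here, in either direction. The expected step is small (a 1.0-fold higher number from compound 2 to compound 3 (0.02 log units; within the scatter)), and the estimate stays close to compound 2 (28800 nM). Compound 3 is therefore estimated at 30000 nM within an expected range (13000 nM to 60000 nM).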

Compound 3, half-maximal inhibitory concentration: 21100 nM
The estimate for compound 3 lay 1.4-fold (0.15 log units) above the measured number, within the range that was stated.
By their numbers in this assay, from the lowest: compounds 3, 2 and 1 (each within the scatter of the next, the first and the last beyond it).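

Compound 3 carries the same atoms as compound 2, with only the chlorines placed differently on the ring, and in this assay this change to 2,4-dichlorophenyl from 2,6-dichlorophenyl gives a 1.4-fold lower number from compound 2 to compound 3 (0.14 log units; within the scatter). The two chlorine patterns therefore cannot be told apart at this place on a saturated chain carbon bound to an amine nitrogen in a ring. Among the compounds shown here, the exchange of 4-nitrophenyl for 2,4-dichlorophenyl gives a 2.2-fold lower number from compound 1 to compound 3 (0.34 log units; beyond the scatter), the first step in this short series to pass the scatter, though it is modest and compound 2 lies within the scatter of both neighbours, so the three compounds form a continuous run rather than two separate groups. No measurement here bears on why these groups give these numbers.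

The compounds shown leave open whether a phenyl with a single chlorine, an unsubstituted phenyl or a pyridine at this place would shift the number further in either direction. They also leave open whether a change elsewhere on the shared core, such as replacing the primary carboxamide with a nitrile, would produce a larger step than any seen at this position.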